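A few compounds are considered here, and "the series" means these few. Any claim that something is new, unique, unknown or untested is made for them only; others in the source may bear on it.

In a functional assay on SK-MEL cells (Homo sapiens) for cytotoxicity, read by MTT assay, with a stated time of 6 days (a lower number here means that less compound is needed, a higher number that more compound is needed for the effect), compound 1 `COc1cc(-c2cc(=O)c3ccc(O)cc3o2)cc(OC)c1OC` gives > 25 ug/mL, which is a limit of the assay and not a number. Compound 2 `COc1cc(-c2cc(=O)c3ccc(O)c(O)c3o2)cc(OC)c1OC` gives > 25 ug/mL, which is also a limit. Compound 2 therefore stands at the limit of > 25 ug/mL in this assay, at which 2 of the 3 values shown sit. Between these two lies a step that the two limits leave unreadable from compound 1 to compound 2, so this step offers no size to build on.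

Compound 3 `COc1cc(-c2cc(=O)c3cc(O)ccc3o2)cc(OC)c1O[Si](C)(C)C(C)(C)C` gives a true number, 2.95 ug/mL. It carries the silicon-bearing group but differs from compound 2 in its hydroxy groups as well.

Compound 4 `COc1cc(-c2cc(=O)c3ccc(O)c(O)c3o2)cc(OC)c1O[Si](C)(C)C(C)(C)C` arises from compound 2 through one change: a group of 7 heavy atoms (6 carbon, 1 silicon; no ring) in place of one carbon atom, on an oxygen on an aromatic ring. Among the measured compounds shown here, no measured step isolates this swap, so the expectation rests on a single neighbour. Going by compound 3 at 2.95 ug/mL, a large step towards less compound needed is expected in this assay, though the extra hydroxy group makes this uncertain. The expected size is an at least 6.2-fold lower number from compound 2 to compound 4 (0.79 log units; beyond the scatter). For compound 4 the estimate is 4 ug/mL, with an expected range from 1.2 ug/mL to 15 ug/mL.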

Compound 4, concentration for half-maximal effect: 0.11 ug/mL
Compound 4: the middle estimate sits 36-fold (1.56 log units) above what was measured; measured number below the stated range.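

Only now does a pair of compounds isolate this swap: on the oxygen on an aromatic ring, with the rest of the structure unchanged, replacing the methyl with the silicon-bearing group of 7 heavy atoms gives in this assay an at least 220-fold lower number from compound 2 to compound 4 (2.35 log units; beyond the scatter). This shows that a change at this single oxygen can turn a compound at the assay limit into one with a true, low reading. The step is a minimum and not an exact size, since compound 2 gives a limit and not a number: the limit of > 25 ug/mL in this assay, at which 2 of the 4 values shown sit.

Going by these compounds, only methyl and this one silicon-bearing group are compared at this oxygen, so it remains open whether a benzyl group or a longer carbon chain such as hexyl would act alike. On these data alone, the step that adds a hydroxy group cannot be read, so the part played by the hydroxy groups in compound 4 also stays open.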